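The compounds below may be only part of what the source reports. "The series", "measured", "known", "first", "only" and "open" are said of these compounds alone.

Measured so far:
compound 1 `C/C(=N\NC(=O)COc1cccc2ccccc12)c1ccc(C#N)cc1Br` — 12.7 ug/mL
compound 2 `O=C(COc1cccc2ccccc12)N/N=C/c1ccc([N+](=O)[O-])cc1` — 14.2 ug/mL

In an ADME assay on HEL cells (Homo sapiens) for cytotoxicity (a higher number here means that more compound is tolerated, a lower number that less compound is tolerated), compound 1 gives 12.7 ug/mL and compound 2 gives 14.2 ug/mL. Compound 2 has the higher of the two numbers, but its gap to compound 1 lies within the scatter, so the two compounds cannot be told apart on this assay. Going by the values given here, no step between them is counted, since they differ in more than one place.

Compound 3 `Cc1ccc(/C=N/NC(=O)COc2cccc3ccccc23)cc1` has not yet been measured. It differs from compound 2 in one place: methyl in place of nitro on an aromatic carbon. Because compound 1 gives 12.7 ug/mL and compound 2 gives 14.2 ug/mL, two numbers that sit within the scatter of each other despite their different groups, no step beyond the scatter is expected for compound 3, in either direction. The step from compound 2 is estimated at a 1.1-fold lower number from compound 2 to compound 3 (0.02 log units; within the scatter). Compound 3 is therefore expected to give about 13.5 ug/mL in this assay, in a range from 6.5 ug/mL to 28 ug/mL.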

Compound 3, half-maximal cytotoxic concentration: 80.1 ug/mL
Estimate against measurement, compound 3: 5.9-fold (0.77 log units) below; the measured number lies above the stated range.
By their numbers in this assay, from the lowest: compounds 1 and 2 (each within the scatter of the next); then compound 3.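

In this assay methyl in place of nitro on an aromatic carbon, para to a large group, brings a 5.6-fold higher number from compound 2 to compound 3 (0.75 log units; beyond the scatter) and so marks this position as one where more compound can be tolerated. Going by these compounds alone, compounds 1 and 2 could not show this, since they differ in more than one place and their numbers lie within the scatter of each other; this single-place change is the first to show that the group on this carbon can move the number beyond the scatter. Nothing measured here explains why the swap has this effect.

As far as these compounds go, with only nitro and methyl compared at this position, and in this one pair, it remains open whether the gain comes from losing nitro or from gaining methyl. An amine, a chlorine atom or a longer alkyl chain on the same carbon would help to separate the two readings.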